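The source may hold more compounds than are shown below. What is called first, only, known or untested is meant among the compounds shown, and "the series" means these compounds.

Working notes on the series. Compound 1 `COc1cccc(Oc2ccc3cc(NC(=O)c4ccc(OC)c(-c5cccc(OC)c5)c4)c(=O)oc3c2C)c1` is read in a functional assay on SK-BR-3 cells (Homo sapiens) for antiproliferative activity; on this read-out higher numbers stand for weaker inhibition and lower numbers for stronger inhibition. For compound 1 the assay returns only a limit, > 100000 nM, and no number. Compound 2 `COc1ccc(Cc2ccc3cc(NC(=O)c4ccc(OC(C)=O)c(CC=C(C)C)c4)c(=O)oc3c2C)cc1` gives 23500 nM in this assay. Among the measured compounds shown here, no step between measured compounds that differ in one place is available, so compound 1 stands at the limit alone, as the limit of > 100000 nM in this assay, at which 1 of the 2 values shown sits, shows. Compound 3 `COc1ccc(Cc2ccc3cc(NC(=O)c4ccc(OC)c(-c5cccc(OC)c5)c4)c(=O)oc3c2C)cc1` is not yet measured; it differs from compound 1 by 4-methoxybenzyl in place of 3-methoxyphenoxy on an aromatic carbon, in words 4-methoxybenzyl in place of 3-methoxyphenoxy on an aromatic carbon. For the measured compounds named here, compound 2 carries the same 4-methoxybenzyl and gives 23500 nM, a number rather than a limit, so some gain beyond the scatter is expected for compound 3, though with no measured step to lean on the size stays uncertain. For compound 3 the expected step is an at least 2.0-fold lower number from compound 1 to compound 3 (0.30 log units; that floor lies within the scatter), and the estimate is 50000 nM, within 15000 nM to 150000 nM.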

Compound 3, half-maximal inhibitory concentration: > 100000 nM
Compound 3: only a limit was reported (the forecaster's own chance of this, stated with the estimate: 40%); middle value at least 2.0-fold (0.30 log units) away from the limit.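

Compound 3 returns only a limit, as compound 1 does, so no step can be read between compound 1 and compound 3; both stand at the same limit: the limit of > 100000 nM in this assay, at which 2 of the 3 values shown sit.

The compounds shown leave open whether 4-methoxybenzyl in place of 3-methoxyphenoxy changes the read-out at all.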